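This account rests on a few compounds, and the source may have more. Where it says the series, first, only, none or still open, it means among the compounds named here.

Compound 1, `CC(c1nccs1)C(C#N)C#N`: in a functional assay on HepG2 cells (Homo sapiens) for cytotoxicity, read by MTT assay, with a stated time of 48 h (a lower number here means a stronger inhibitor, a higher number a weaker inhibitor), compound 1 gives > 120000 nM, which is a limit of the assay and not a number.
Compound 2, `N#CC(C#N)=Cc1nccs1`: in this assay compound 2 gives > 120000 nM, again a limit rather than a number.

Compound 2 therefore stands nowhere in particular among these numbers: its result is only a limit, and the one other value shown is a limit too. Among the measured compounds shown here, both measured results sit at the limit of > 120000 nM in this assay, at which 2 of the 2 values shown sit, so no step between measured compounds can be drawn, and neither compound can be called weaker or stronger than the other.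

Compound 3, `CC(=C(C#N)C#N)c1nccs1`, has not yet been tested in this assay. It differs from compound 2 by methyl in place of hydrogen on a double-bonded chain carbon bound to an aromatic carbon and a double-bonded chain carbon. With both neighbours sitting at the limit, no change beyond the usual scatter is expected from compound 2 to compound 3; the most likely outcome is that compound 3 also reaches only a limit. The step that the limit leaves unreadable from compound 2 to compound 3 is my estimate, not a measured one. For compound 3 in this assay the expected value is 150000 nM, with a range from 60000 nM to 400000 nM.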

Compound 3, half-maximal inhibitory concentration: 105000 nM
Beside the measured number, compound 3's estimate is 1.4-fold (0.15 log units) above it; measured number inside the range.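

Compound 3 is the only one of the three compounds that gives a number rather than a limit in this assay: the limit of > 120000 nM in this assay, at which 2 of the 3 values shown sit.

With methyl in place of hydrogen on a double-bonded chain carbon bound to an aromatic carbon and a double-bonded chain carbon, the data give an at least 1.1-fold lower number from compound 2 to compound 3 (0.05 log units; that floor lies within the scatter). This step is only a floor, as one end of it is a limit, so the true size of the change cannot be read: it may be no real change at all, or it may be a larger one. What the new result does add is that this position can carry a methyl group while compound 3 gives 105000 nM as a measurable number.

Going by these compounds, whether a longer chain or an amine on this same carbon would shift the number clearly beyond the usual scatter remains open. Also open, on these data alone, is whether a larger change elsewhere on the shared core, such as a carboxylic acid in place of a nitrile, would matter more than this single methyl.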